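Phenyl in Place of Cyclopentyl on the Ring Amide Nitrogen

The compounds below may be only part of what the source reports. "The series", "measured", "known", "first", "only" and "open" are said of these compounds alone.

Compound 3 `Cc1cc2c(c(Oc3cccc(NS(=O)(=O)c4ccc(Cl)cc4)c3)n1)C(=O)N(C1CCCC1)C2=O` gives 95% in a functional assay on HEK293 cells for agonist activity at Glucose-dependent insulinotropic receptor (Homo sapiens), read by cAMP accumulation, with a stated time of 30 min (a higher number here means a larger maximal response, a lower number a smaller maximal response), the lowest of the three measured numbers. In this assay compound 1 `Cc1cc2c(c(Oc3cccc(NS(=O)(=O)c4ccc(Cl)cc4)c3)n1)C(=O)N(C)C2=O` gives 122%, and compound 2 `CCN1C(=O)c2cc(C)nc(Oc3cccc(NS(=O)(=O)c4ccc(Cl)cc4)c3)c2C1=O` gives 120%. Exchanging methyl for ethyl on the amide-type nitrogen produced a number 2 percentage points lower from compound 1 to compound 2 (within the scatter), whereas bringing in cyclopentyl produced a number 27 percentage points lower from compound 1 to compound 3 (beyond the scatter) and a number 25 percentage points lower from compound 2 to compound 3 (beyond the scatter). Both steps that changed the substituent on this nitrogen beyond a small alkyl group lowered the maximal response by a modest amount.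

Compound 4 `Cc1cc2c(c(Oc3cccc(NS(=O)(=O)c4ccc(Cl)cc4)c3)n1)C(=O)N(c1ccccc1)C2=O` differs from compound 3 in one place: phenyl in place of cyclopentyl on an amide-type nitrogen in a ring. The two informative steps, from compound 1 and compound 2 to compound 3, concern a move from a small alkyl group to a five-membered carbocycle; the move from cyclopentyl to phenyl keeps a ring of comparable size, so little further change is expected in this assay. Compound 4 is therefore estimated at 90%, with a range from 70% to 110%, meaning an expected step of a number 5 percentage points lower from compound 3 to compound 4 (within the scatter).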

Compound 4, largest response reached (reported as efficacy), in percent of the reference or control that the assay uses: 102%
Estimate against measurement, compound 4: 12 percentage points below; the measured number falls inside the stated range.
By their numbers in this assay, from the lowest: compounds 3 and 4 (each within the scatter of the next); then compounds 2 and 1 (each within the scatter of the next).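

In this assay, the step of a number 7 percentage points higher from compound 3 to compound 4 (within the scatter) shows that a six-membered aromatic ring of carbon only on the amide-type nitrogen cannot be told apart from the five-membered non-aromatic ring. Phenyl also gives a number 18 percentage points lower from compound 2 to compound 4 (beyond the scatter) and a number 20 percentage points lower from compound 1 to compound 4 (beyond the scatter) against the small alkyl groups, so the lower maximal response at this nitrogen is not confined to cyclopentyl among the compounds shown. Nothing measured here explains this shared behaviour of the two rings.

The compounds leave open whether a benzyl group, with a single carbon placed between this nitrogen and the phenyl ring, would behave like phenyl or like the small alkyl groups. They also leave open what a pyridine ring, a longer chain such as butyl, or a chain ending in an amine or a carboxylic acid would give at this nitrogen.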